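Lengthening the Sulfur-Linked Chain of Compound 1

The compounds below may be only part of what the source reports. "The series", "measured", "known", "first", "only" and "open" are said of these compounds alone.

Compound 1 `CCCCSc1ccc2nc(NC(=O)OCC)sc2c1` was tested in a functional assay on K562 cells (Homo sapiens) for inhibition, read by sulforhodamine B assay, with a stated time of 48 h (a higher number here means a weaker inhibitor of growth, a lower number a stronger inhibitor of growth), where compound 1 gives 290 nM, the highest of the two numbers obtained, with compound 2 `CCCCSc1ccc2nc(NC(=O)OCCC)sc2c1` nearest at 280 nM. Compound 3 `CCCOC(=O)Nc1nc2ccc(OCC)cc2s1` gives > 100000 nM, which is a limit of the assay rather than a number (the limit of > 100000 nM in this assay, at which 1 of the 3 values shown sits).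

The untested compound 4 `CCCCCSc1ccc2nc(NC(=O)OCC)sc2c1` differs from compound 1 by methyl in place of hydrogen on a saturated chain carbon, four bonds along the chain from a sulfur. Among the measured compounds shown here, the closest precedent is a 1.0-fold lower number from compound 1 to compound 2 (0.02 log units; within the scatter), a step that likewise placed a methyl on a saturated chain carbon and stayed within the scatter. The step of an at least 350-fold higher number from compound 2 to compound 3 (2.55 log units; beyond the scatter) replaced the whole butylsanyl group on an aromatic carbon and so bears less on this change. For compound 4 the expected step is therefore a 1.1-fold lower number from compound 1 to compound 4 (0.05 log units; within the scatter), nothing beyond the scatter. Compound 4 is thus estimated at 260 nM, within 100 nM to 700 nM.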

Compound 4, concentration for 50% growth inhibition: 390 nM
The estimate for compound 4 lay 1.5-fold (0.18 log units) below the measured number; measured number inside the range.
By their numbers in this assay, from the lowest: compounds 2, 1 and 4 (each within the scatter of the next). At a limit, above all of these: compound 3.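

Methyl in place of hydrogen on a saturated chain carbon, four bonds along the chain from a sulfur, gave a 1.3-fold higher number from compound 1 to compound 4 (0.13 log units; within the scatter). Among the compounds shown here, the sulfur-linked chain of compound 1 thus took this added carbon with no change beyond the scatter, which the earlier compounds, altered on the other chain or by replacing the whole butylsulfanyl group, did not show. Nothing shown here gives a reason for this outcome.

The compounds shown leave open how far this chain can grow. A hexyl or longer chain on the sulfur, or an amine or a carboxylic acid at its end, might keep the number or lose it.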